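This account rests on a few compounds, and the source may have more. Where it says the series, first, only, none or still open, it means among the compounds named here.

Compound 3, with the structure `COc1ccc(C(=O)c2sc(Nc3ccccc3)c(C(=O)O)c2C)cc1`, stands highest of the two numbers available: in a functional assay, with a stated time of 150 min, tested at 30 ug/mL (a lower number here means a weaker effect, a higher number a stronger effect of the compound at the concentration tested), compound 3 gives 59.5%. Its nearest neighbour is compound 1, `COC(=O)c1c(Nc2ccccc2)sc(C(=O)c2ccc(OC)cc2)c1C`, which in this assay gives 48.1%; the step of a number 11.4 percentage points higher from compound 1 to compound 3 (beyond the scatter) comes from hydrogen in place of methyl on an oxygen next to a carbonyl group. Compound 2, `COC(=O)c1c(Nc2ccc(F)cc2)sc(C(=O)c2ccc(C)cc2)c1C`, is reported in this assay as "not active" (no number reported), without a number; it differs from compound 3 in more than one place, so nothing can be drawn from it alone.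

Compound 4, `COc1ccc(C(=O)c2sc(Nc3ccc(Cl)cc3)c(C(=O)O)c2C)cc1`, differs from compound 3 by chloro in place of hydrogen on an aromatic carbon. For the measured compounds named here, no measured step alters the phenyl of the anilino group, so no step bears directly on this change, and the single measured step concerns a different part of the core. The expected step of a number 7.5 percentage points lower from compound 3 to compound 4 (within the scatter) is therefore small, within the scatter or slightly downward. Compound 4 is estimated to give 52% in this assay, in a range from 25% to 75%.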

Compound 4, a percentage reported as activity, at one concentration (the size of the read-out at that concentration, not a potency): "not active" (no number reported)
For compound 4 the study gives words and no number, so the estimate cannot be set against anything.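

For the compounds shown here, compound 4 is reported in this assay in words only, so no step from compound 3 to compound 4 can be read, and nothing available bears on this result. The compounds shown leave open how chloro in place of hydrogen on the anilino group changes the read-out.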